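The compounds below may be only part of what the source reports. "The series", "measured", "known", "first", "only" and "open" are said of these compounds alone.

Compound 1 `Cc1cn2c(/C=N/NC(=N)N)c(-c3ccsc3)nc2s1`: 22400 nM
Compound 2 `N=C(N)N/N=C/c1c(-c2cccs2)nc2sccn12`: 28200 nM

In a functional assay on cells (Cancer cell lines, Homo sapiens) for inhibition (on this read-out higher numbers stand for weaker inhibition of growth and lower numbers for stronger inhibition of growth), compound 2 stands at 28200 nM, a value within the scatter of that of compound 1, 22400 nM. Compound 3 `Cc1cn2c(/C=N/NC(=N)N)c(-c3cccs3)nc2s1` is built from compound 2 by one change: methyl in place of hydrogen on an aromatic carbon. Among the compounds with values here, no measured pair isolates this change, so no step beyond the scatter is expected in this assay, in either direction. The expected outcome is a 1.2-fold lower number from compound 2 to compound 3 (0.07 log units; within the scatter). Compound 3 is estimated at 24000 nM, with an expected range of 12000 nM to 50000 nM.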

Compound 3, concentration for total growth inhibition: 18600 nM
Beside the measured number, compound 3's estimate is 1.3-fold (0.11 log units) above it; measured number inside the range.
By their numbers in this assay, from the lowest: compounds 3, 1 and 2 (each within the scatter of the next).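

In this assay methyl in place of hydrogen on an aromatic carbon next to the ring sulfur gives a 1.5-fold lower number from compound 2 to compound 3 (0.18 log units; within the scatter) and so leaves the number within the scatter at this position. With that methyl present, thiophen-2-yl in place of thiophen-3-yl gives a 1.2-fold lower number from compound 1 to compound 3 (0.08 log units; within the scatter) and also stays within the scatter. Nothing available explains either result.

As far as these compounds go, whether an ethyl, an amine or a carboxylic acid at this position would move the number beyond the scatter remains open. So does whether a phenyl in place of either thiophene would.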